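Dropping One Methoxy Group: Compound 2 to Compound 3

This account rests on a few compounds, and the source may have more. Where it says the series, first, only, none or still open, it means among the compounds named here.

Within the data shown here, compound 2 `COc1ccc(C(=O)/C=C/c2cc(-c3cc(OC)c(OC)c(OC)c3)n[nH]2)cc1OC` is one of two compounds measured so far; in a functional assay on OVCAR-3 cells (Homo sapiens) for inhibition, read by sulforhodamine B assay, with a stated time of 48 h (on this read-out lower numbers stand for stronger inhibition of growth and higher numbers for weaker inhibition of growth), compound 2 gives 1680 nM. Compound 1 `COc1cc(-c2cc(/C=C/C(=O)c3ccc(N)cc3)[nH]n2)cc(OC)c1OC` gives 1570 nM in this assay, and the two sit within the usual scatter of each other, as a 1.1-fold higher number from compound 1 to compound 2 (0.03 log units; within the scatter) shows. Compound 3 `COc1ccc(C(=O)/C=C/c2cc(-c3cc(OC)c(OC)c(OC)c3)n[nH]2)cc1` differs from compound 2 by hydrogen in place of methoxy on an aromatic carbon. Among the measured compounds shown here, no measured step removes a methoxy group in this way; the one recorded step, which exchanges the whole aryl group on the carbonyl carbon, barely moved the number, so a step within the scatter is expected, with a 1.2-fold higher number from compound 2 to compound 3 (0.08 log units; within the scatter). Compound 3 is estimated at 2000 nM, ranging from 900 nM to 4500 nM.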

Compound 3, concentration for 50% growth inhibition: 1740 nM
The estimate for compound 3 lay 1.1-fold (0.06 log units) above the measured number; low and high end bracket the measured number.
By their numbers in this assay, from the lowest: compounds 1, 2 and 3 (each within the scatter of the next).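

In this assay the loss of one methoxy group, 3,4-dimethoxyphenyl to 4-methoxyphenyl, stays within the scatter (a 1.0-fold higher number from compound 2 to compound 3 (0.02 log units; within the scatter)). The exchange of amino for methoxy also stays within the scatter (a 1.1-fold higher number from compound 1 to compound 3 (0.04 log units; within the scatter)), so 4-aminophenyl, 4-methoxyphenyl and 3,4-dimethoxyphenyl on the carbonyl carbon cannot be told apart here. No measured evidence explains this result. Going by these compounds, whether a carboxylic acid on this ring would give a different number stays open, and so does the outcome with a longer chain such as butoxy in place of methoxy.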